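The compounds below may be only part of what the source reports. "The series", "measured", "known", "first", "only" and "open" are said of these compounds alone.

Measured so far:
- compound 1 `CCCN(CCC)c1ccc(NC(=O)c2cc(Cl)ccc2O)c(Cl)c1`: 10700 nM
- compound 2 `O=C(Nc1ccc(NCc2cc(Cl)cc(C(F)(F)F)c2)cc1Cl)c1cc(Cl)ccc1O`: 30900 nM
- compound 3 `O=C(Nc1ccc(NCc2cc(F)cc(C(F)(F)F)c2)cc1Cl)c1cc(Cl)ccc1O`: 30900 nM

In an ADME assay on A549 cells (Homo sapiens) for cytotoxicity, read by resazurin assay, with a stated time of 48 h (on this read-out lower numbers stand for higher toxicity in this test and higher numbers for lower toxicity in this test), compound 1 gives the lowest of the three numbers; compounds 2 and 3 both sit higher, and the gap from compound 1 to either of them lies beyond the scatter. Compound 1 is thus the most toxic of the three in this test. Between compound 2 and compound 3 the only measured step, no change at the digits printed from compound 2 to compound 3 (within the scatter), shows that a halogen swap on the outer ring leaves the read-out where it was.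

Compound 4 `O=C(Nc1ccc(NCc2cnccc2Cl)cc1Cl)c1cc(Cl)ccc1O` is not yet measured. Compared with compound 1 the change is ((4-chloropyridin-3-yl)methyl)amino in place of dipropylamino on an aromatic carbon. Within the data shown here, no measured step covers exactly this exchange; what bears on it is that compounds 2 and 3, which likewise carry an arylmethylamino group in place of the dipropylamino group of compound 1, both give higher numbers than compound 1 in this assay, and the step between them shows the outer ring tolerates a change of substituent without effect. The number for compound 4 is therefore expected to rise, with a step of a 2.3-fold higher number from compound 1 to compound 4 (0.37 log units; beyond the scatter). The estimate for compound 4 is 25000 nM, within 10000 nM to 60000 nM.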

Compound 4, half-maximal cytotoxic concentration: 126000 nM
Beside the measured number, compound 4's estimate is 5.0-fold (0.70 log units) below it, and the stated range ends below it.
By their numbers in this assay, from the lowest: compound 1; then compounds 2 and 3 (each within the scatter of the next); then compound 4.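

In this assay, the position meta to a chloro group and para to a large group proves sensitive to what it carries: ((4-chloropyridin-3-yl)methyl)amino in place of dipropylamino gives a 12-fold higher number from compound 1 to compound 4 (1.07 log units; beyond the scatter). Among these compounds, the only earlier step, no change at the digits printed from compound 2 to compound 3 (within the scatter), was a halogen swap on the outer ring and showed no such movement, so the series now has a large change to set against a flat one. Nothing on hand explains the size of this step.

The compounds shown leave open whether the ring nitrogen, the chlorine on that ring or the amino hydrogen accounts for the step. A plain benzylamino group or a methylamino group at the same position would help to separate these contributions.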